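A few compounds are considered here, and "the series" means these few. Any claim that something is new, unique, unknown or untested is made for them only; others in the source may bear on it.

Measured compounds:
compound 1 `CC/C=C/CC(=O)OCC1COCCOCCOCCOCCOCCO1`; in a functional assay on SW1573 cells (Homo sapiens) for inhibition, read by sulforhodamine B assay, with a stated time of 48 h (on this read-out higher numbers stand for weaker inhibition of growth and lower numbers for stronger inhibition of growth), compound 1 gives > 100000 nM, a limit of the assay.
compound 2 `CC(=O)OCC1COCCOCCOCCOCCOCCO1`; in this assay compound 2 gives > 100000 nM, likewise a limit.

Among the compounds with values here, compound 2 thus stands at the limit, and so does the only other measured compound, as the limit of > 100000 nM in this assay, at which 2 of the 2 values shown sit, records. The step that the two limits leave unreadable from compound 1 to compound 2, which replaces but-1-en-1-yl with hydrogen on a saturated chain carbon bound to a carbonyl carbon, has no readable size; both of its ends are limits. Compound 3 `O=C(CCCc1cc2ccccc2[nH]1)OCC1COCCOCCOCCOCCOCCO1` differs from compound 2 by 2-(1H-indol-2-yl)ethyl in place of hydrogen on a saturated chain carbon bound to a carbonyl carbon. Within the data shown here, only that one measured step bears on this change, and it yields no size or direction, so nothing in the numbers points to a step beyond the scatter in this assay. Compound 3 is therefore expected to sit near the same limit, with a number no higher from compound 2 to compound 3 (the limit leaves the size open). The estimated value of compound 3 in this assay is 100000 nM, within a range from 30000 nM to 300000 nM.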

Compound 3, concentration for 50% growth inhibition: > 100000 nM
Compound 3 was reported as a limit; the forecaster's own chance of this, stated with the estimate: 75%; the middle value sits exactly at the limit.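

No new step can be read from compound 3, which also gives only a limit, so its steps to compound 1 and compound 2 stay unreadable in this assay and the record remains: the limit of > 100000 nM in this assay, at which 3 of the 3 values shown sit.

The compounds shown leave open how far each lies past that limit, and whether any change at this place on the shared core brings growth inhibition into measurable range.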